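Compound 4: One More Group Swap on a Shared Core

This account rests on a few compounds, and the source may have more. Where it says the series, first, only, none or still open, it means among the compounds named here.

In a physicochemical assay for lipophilicity, using the shake flask method, measured as octanol-water partition, at pH 7.4 (on this read-out higher numbers stand for higher lipophilicity and lower numbers for lower lipophilicity), compound 3 (`CC(=O)N[C@@H]1CCC[C@H](C(=O)Nc2cc(-c3nnn4ccccc34)c(Cl)cn2)C1`) gives 2, within the scatter of compound 2 (`CC(=O)N[C@@H]1CCC[C@H](C(=O)Nc2cc(-c3cnc(C)n3C)c(Cl)cn2)C1`) at 2.2, and both stand well under compound 1 (`CC(=O)N[C@@H]1CCC[C@H](C(=O)Nc2cc(-c3cnn4ccccc34)c(Cl)cn2)C1`) at 3.6. Compound 4 (`CC(=O)N[C@@H]1CCC[C@H](C(=O)Nc2cc(-c3cnn4c3CCC4)c(Cl)cn2)C1`) differs from compound 3 in one group: a group of 8 heavy atoms (6 carbon, 2 nitrogen; one five-membered non-aromatic ring with 1 hetero atom, one five-membered aromatic ring with 2 hetero atoms) in place of a group of 9 heavy atoms (6 carbon, 3 nitrogen; one five-membered aromatic ring with 3 hetero atoms, one six-membered aromatic ring with 1 hetero atom), on an aromatic carbon. Like the group in compound 2, the new group has no six-membered aromatic ring. Two large steps bear on this, a number 1.40 log units lower from compound 1 to compound 2 (beyond the scatter) and a number 1.60 log units lower from compound 1 to compound 3 (beyond the scatter), while a number 0.20 log units lower from compound 2 to compound 3 (within the scatter) stays within the scatter. Only compound 1 stands apart, so a large step seems unlikely here. The expected change is small and upward, a number 0.30 log units higher from compound 3 to compound 4 (within the scatter), no larger than the scatter. For compound 4 the estimated value is 2.3, with an expected range from 1.8 to 2.8.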

Compound 4, distribution coefficient: 2.9
Compound 4: middle estimate off by 0.60 log units, on the low side, outside the stated range (above it).
By their numbers in this assay, from the lowest: compounds 3 and 2 (each within the scatter of the next); then compound 4; then compound 1.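

This group places the read-out in this assay at a middle level on the shared core: a number 0.90 log units higher from compound 3 to compound 4 (beyond the scatter), a number 0.70 log units higher from compound 2 to compound 4 (beyond the scatter), and a number 0.70 log units lower from compound 1 to compound 4 (beyond the scatter). Having no six-membered aromatic ring therefore does not settle the number at this position, since compound 2 and compound 4 both lack one yet differ beyond the scatter, and compound 1 and compound 3 both carry one yet also differ beyond the scatter.

No measurement here gives a cause for these steps. On these data alone, how an amine or a carboxylic acid would read at this position remains open.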